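This account rests on a few compounds, and the source may have more. Where it says the series, first, only, none or still open, it means among the compounds named here.

Compound 1 `CSc1nc(Br)c(C(=O)c2ccccc2)s1` and compound 2 `O=C(c1ccccc1)c1sc(N2CCCC2)nc1Br` share one core, while compound 3 `COC(=O)c1sc2nc(SC)sc2c1C` is built on another; the difference between the two cores is not broken down here. In a functional assay on PC-3 cells (Homo sapiens) for cytotoxicity, read by MTT assay, with a stated time of 72 h (a higher number here means a weaker inhibitor, a lower number a stronger inhibitor), compound 1 gives > 100000 nM, which is a limit of the assay and not a number. Compound 2 also gives only a limit, > 100000 nM. The change pyrrolidin-1-yl in place of methylsulfanyl on an aromatic carbon thus made a step that the two limits leave unreadable from compound 1 to compound 2 because of the limit of > 100000 nM in this assay, at which 2 of the 3 values shown sit. Compound 3 gives 90000 nM in this assay. Compound 4 `COC(=O)c1sc2nc(N3CCCC3)sc2c1C` is not yet measured and differs from compound 3 by pyrrolidin-1-yl in place of methylsulfanyl on an aromatic carbon, the same kind of change, though here the place is part of a fused or bridged system of two rings. With the earlier step unreadable, compound 4 is expected to give 90000 nM, between 30000 nM and 200000 nM. That estimate means a step of no change at the digits printed from compound 3 to compound 4 (within the scatter), resting on compound 3 at its measured 90000 nM.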

Compound 4, half-maximal inhibitory concentration: > 100000 nM
Compound 4: no number, only a limit (the forecaster's own chance of this, stated with the estimate: 55%); middle value at least 1.1-fold (0.04 log units) from the limit.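

In this assay, pyrrolidin-1-yl in place of methylsulfanyl on the core of compound 3 gave an at least 1.1-fold higher number from compound 3 to compound 4 (0.04 log units; that floor lies within the scatter); compound 4 reads only as a limit of the assay, so this is a floor and not a size. What this shows is narrow: with pyrrolidin-1-yl, compound 2 and compound 4 both give only a limit on their two cores. It does not show whether the change has the same size on both cores, as the step on the core of compound 1 cannot be read: the limit of > 100000 nM in this assay, at which 3 of the 4 values shown sit.

The compounds shown leave open whether another amine, such as morpholine or piperazine, would give a readable number on either core. They also leave open what a carboxylic acid in place of the methyl ester of compound 3 would give.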